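A Repeated Dimethoxyphenyl Swap and Its Expected Cost

This account rests on a few compounds, and the source may have more. Where it says the series, first, only, none or still open, it means among the compounds named here.

Compound 1 `COc1ccc(Nc2nc3ccccc3nc2S(=O)(=O)c2ccc(Br)cc2)cc1` and compound 3 `COc1ccc(Nc2nc3ccccc3nc2S(=O)(=O)c2ccc(F)cc2)cc1` share one core, and the difference between them is fluoro in place of bromo on an aromatic carbon. In a functional assay on HL-60 cells (Homo sapiens) for cytotoxicity, read by MTT assay, with a stated time of 72 h (a lower number here means a stronger inhibitor, a higher number a weaker inhibitor), compound 1 gives 1190 nM, and compound 3 gives 1200 nM; the step of a 1.0-fold higher number from compound 1 to compound 3 (0.00 log units; within the scatter) lies within the scatter. Compound 2 `COc1cc(Nc2nc3ccccc3nc2S(=O)(=O)c2ccc(Br)cc2)cc(OC)c1` carries the change (3,5-dimethoxyphenyl in place of 4-methoxyphenyl on a nitrogen on an aromatic ring); in this assay compound 2 gives 2540 nM, a step of a 2.1-fold higher number from compound 1 to compound 2 (0.33 log units; beyond the scatter). Compound 4 `COc1cc(Nc2nc3ccccc3nc2S(=O)(=O)c2ccc(F)cc2)cc(OC)c1` has not been measured. Its difference from compound 3 is 3,5-dimethoxyphenyl in place of 4-methoxyphenyl on a nitrogen on an aromatic ring, the same change that turned compound 1 into compound 2, with the same surroundings at the place of change in both cases. Because a 2.1-fold higher number from compound 1 to compound 2 (0.33 log units; beyond the scatter) was modest and beyond the scatter, and because a 1.0-fold higher number from compound 1 to compound 3 (0.00 log units; within the scatter) shows the two cores behaving alike, compound 4 is expected to show a step of a 2.1-fold higher number from compound 3 to compound 4 (0.32 log units; beyond the scatter) in this assay. The estimate for compound 4 in this assay is 2500 nM, expected to lie between 1200 nM and 5500 nM.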

Compound 4, half-maximal inhibitory concentration: 2360 nM
Compound 4: the middle estimate sits 1.1-fold (0.03 log units) above what was measured, within the range that was stated.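

In this assay the move to 3,5-dimethoxyphenyl on the fluoro compounds (a 2.0-fold higher number from compound 3 to compound 4 (0.29 log units; within the scatter)) matches the same move on the bromo compounds: the same change on two cores in this assay, a 2.1-fold higher number (0.33 log units; beyond the scatter) from compound 1 to compound 2 and a 2.0-fold higher number (0.29 log units; within the scatter) from compound 3 to compound 4, 1.1-fold (0.04 log units) apart, within the scatter of two such steps. The change from bromo to fluoro, read with 3,5-dimethoxyphenyl in place (a 1.1-fold lower number from compound 2 to compound 4 (0.03 log units; within the scatter)), also matches its earlier counterpart: the same change on two cores in this assay, a 1.0-fold higher number (0.00 log units; within the scatter) from compound 1 to compound 3 and a 1.1-fold lower number (0.03 log units; within the scatter) from compound 2 to compound 4, 1.1-fold (0.04 log units) apart, within the scatter of two such steps. The two changes therefore carried over between these two cores, although the step is small enough to lie beyond the scatter in one case and within it in the other, and a single square of four compounds does not show that this would hold for other groups.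

The compounds shown leave open how a chloro or trifluoromethyl group would behave in place of the halogen. They also leave open whether a morpholine or a carboxylic acid in place of the methoxy groups would follow the same pattern.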